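Cytotoxicity in Jurkat cells: dichlorophenyl to dimethylphenyl swap

The source may report more compounds than this note shows. Statements on the series, on what has been measured and on what is new or still open speak of the compounds shown alone.

Of the compounds shown here, two have been measured in a functional assay on Jurkat cells (Homo sapiens) for cytotoxicity, read by MTT assay, with a stated time of 24 h; a higher number here means that more compound is needed for the effect, a lower number that less compound is needed. Compound 1 `CCCCC#Cc1cc(C(=O)OCC)nc2ccc(OC)cc12` gives 15900 nM in this assay. Compound 2 `COc1ccc2nc(-c3c(Cl)cccc3Cl)cc([Se]c3ccccc3)c2c1` gives 17000 nM in this assay, a number that lies within the scatter of the one for compound 1, so the two cannot be told apart on the numbers shown. Among the measured compounds shown here, the two differ at several places, so no single step between them can be drawn.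

Compound 3 `COc1ccc2nc(-c3c(C)cccc3C)cc([Se]c3ccccc3)c2c1` is the next member and has not yet been measured in this assay. It carries 2,6-dimethylphenyl in place of 2,6-dichlorophenyl on an aromatic carbon relative to compound 2. For the measured compounds named here, no measured pair isolates such a change, so there is no step on which to rest a direction. The step from compound 2 to compound 3 is expected to be small, no change at the digits printed from compound 2 to compound 3 (within the scatter), and not beyond the scatter. In this assay compound 3 is therefore expected at 17000 nM, with a range from 6000 nM to 50000 nM.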

Compound 3, half-maximal effective concentration: 26900 nM
Compound 3: the middle estimate sits 1.6-fold (0.20 log units) below what was measured, within the range that was stated.
By their numbers in this assay, from the lowest: compounds 1, 2 and 3 (each within the scatter of the next).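

In this assay, among the compounds shown here, the first pair that differs in one place gives a 1.6-fold higher number from compound 2 to compound 3 (0.20 log units; within the scatter), with 2,6-dimethylphenyl in place of 2,6-dichlorophenyl on the aromatic carbon next to the ring nitrogen. At this position, the two groups, each of 8 heavy atoms, cannot be told apart on these numbers, so the swap of both chlorines for methyl groups gives no readable change here. Nothing available on these compounds bears on this step.

Still open, from the compounds shown here alone, is whether an unsubstituted phenyl, or a phenyl carrying an amine or a carboxylic acid, at this place would give a step beyond the scatter. Also open, going by these compounds, is what a longer chain in place of the group of 7 heavy atoms would do on the same core.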